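The compounds below may be only part of what the source reports. "The series", "measured", "known", "first", "only" and "open" are said of these compounds alone.

Measured in a functional assay on HCT-15 cells (Homo sapiens) for cytotoxicity; on this read-out lower numbers stand for an effect already at smaller amounts and higher numbers for an effect only at larger amounts of compound:
- Compound 1 `CCCCC/C=C\C/C=C\C/C=C\C[C@@]1(OC)C=CC(=O)O1`: 8.9 ug/mL
- Compound 2 `CC/C=C\C/C=C\C/C=C\C/C=C\C[C@]1(OC)C=CC(=O)O1`: 17.5 ug/mL

The values of these two compounds lie within the usual scatter of each other, so compound 2 cannot be ranked against compound 1. Compound 3 `CC/C=C/C/C=C\C/C=C\C/C=C\C[C@@]1(OC)C=CC(=O)O1` has the same atoms and bonds as compound 2: the two compounds have the same atoms and bonds and differ only in configuration as drawn: 2 of 5 stereo elements differ; a stereocentre at a saturated ring carbon is drawn R in compound 2 and S in compound 3; a double bond is drawn Z in compound 2 and E in compound 3. For the measured compounds named here, no measured pair isolates such a change. Going by the values given here, the only guide is that compound 1 at 8.9 ug/mL and compound 2 at 17.5 ug/mL cannot be told apart, so no step beyond the scatter is expected, and no direction can be favoured. The estimated step of a 1.3-fold lower number from compound 2 to compound 3 (0.13 log units; within the scatter) stays within that scatter. For compound 3 the expected value is 13 ug/mL, with an estimated range from 6 ug/mL to 27 ug/mL.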

Compound 3, concentration for half-maximal effect: 34.8 ug/mL
Beside the measured number, compound 3's estimate is 2.7-fold (0.43 log units) below it; measured number above the stated range.
By their numbers in this assay, from the lowest: compounds 1, 2 and 3 (each within the scatter of the next, the first and the last beyond it).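

In this assay, the change in configuration alone gives a 2.0-fold higher number from compound 2 to compound 3 (0.30 log units; within the scatter), so neither the ring stereocentre drawn S nor the double bond drawn E separates compound 3 from compound 2, and the two changes come only together: the fact that compounds 2 and 3 differ only in the configuration as drawn. Placing but-1-en-1-yl in place of butyl on a saturated chain carbon bound to a double-bonded chain carbon gives a 3.9-fold higher number from compound 1 to compound 3 (0.59 log units; beyond the scatter), the first step in this series beyond the scatter, though a modest one.

The compounds shown leave open what each stereo element does on its own, and how a longer chain or a carboxylic acid in place of butyl would read in this assay.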